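The source may hold more compounds than are shown below. What is called first, only, known or untested is meant among the compounds shown, and "the series" means these compounds.

Three compounds share one core and differ only in the group carried on a saturated ring carbon of a six-membered ring. Compound 1 `COCC(=O)NC1CCN(c2nc(C)c3cc(NC(=O)/C=C/c4ccc(OC(F)(F)F)cc4)ccc3n2)CC1` gives 58% in an ADME assay on microsomes from liver (Homo sapiens) for metabolic stability, with a stated time of 30 min; on this read-out higher numbers stand for a more stable compound and lower numbers for a less stable compound. Compound 2 `Cc1nc(N2CCC(N3CCCS3(=O)=O)CC2)nc2ccc(NC(=O)/C=C/c3ccc(OC(F)(F)F)cc3)cc12` gives 85% in this assay, and compound 3 `Cc1nc(N2CCC(N3CCCC3=O)CC2)nc2ccc(NC(=O)/C=C/c3ccc(OC(F)(F)F)cc3)cc12` gives 76%. Among these three numbers compound 3 stands second highest: its nearest neighbour is compound 2, and that gap is within the scatter, while the step of a number 18 percentage points higher from compound 1 to compound 3 (beyond the scatter) lies beyond it.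

Compound 4 `Cc1nc(N2CCC(N3CCN(C)C3=O)CC2)nc2ccc(NC(=O)/C=C/c3ccc(OC(F)(F)F)cc3)cc12` differs from compound 3 in one place: 3-methyl-2-oxoimidazolidin-1-yl in place of 2-oxopyrrolidin-1-yl on a saturated ring carbon. Among the measured compounds shown here, two measured steps bear on this. The step of a number 18 percentage points higher from compound 1 to compound 3 (beyond the scatter) replaced an open chain with a five-membered ring; the step of a number 9 percentage points lower from compound 2 to compound 3 (within the scatter) exchanged one five-membered ring for another and stayed within the scatter. The change to compound 4 is again a swap between two five-membered rings, so no step beyond the scatter is expected in this assay.

Compound 4 is therefore estimated to give 76% in this assay, with a range from 60% to 90%, which would mean an expected step of no change at the digits printed from compound 3 to compound 4 (within the scatter).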

Compound 4, percent of the compound remaining: 33%
The estimate for compound 4 lay 43 percentage points above the measured number, and the stated range ends above it.
By their numbers in this assay, from the lowest: compound 4; then compound 1; then compounds 3 and 2 (each within the scatter of the next).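

In this assay, five-membered rings on this saturated ring carbon turn out not to be interchangeable: 3-methyl-2-oxoimidazolidin-1-yl in place of 2-oxopyrrolidin-1-yl gives a number 43 percentage points lower from compound 3 to compound 4 (beyond the scatter) even though the entering group differs only by one more nitrogen in its count of atoms and has the same count of hydrogen-bond donors and acceptors. The new group also falls short of the other two groups, with a number 52 percentage points lower from compound 2 to compound 4 (beyond the scatter) and with a number 25 percentage points lower from compound 1 to compound 4 (beyond the scatter) as the steps, so the open chain no longer gives the lowest number and carrying a five-membered ring at this position does not by itself go with a high number. Nothing measured here accounts for the size of this drop.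

The compounds shown leave open whether the loss goes with the second ring nitrogen of the entering group or with the methyl on it, a question that the 2-oxoimidazolidin-1-yl ring without the methyl could help to settle. They also leave open how a six-membered lactam, a free amine or a carboxylic acid on this ring carbon would behave in this assay under the same conditions.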